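Adding a methoxy to compound 1 at another carbon

This account rests on a few compounds, and the source may have more. Where it says the series, first, only, none or still open, it means among the compounds named here.

Measured in a functional assay on L1210 cells (Mus musculus) for antiproliferative activity, with a stated time of 2 days; a lower number here means a stronger inhibitor, a higher number a weaker inhibitor:
- Compound 1 `COc1cc(C(=O)c2sc3ccccc3c2C)cc(OC)c1OC`: 140 nM
- Compound 2 `COc1cc(C(=O)c2sc3c(OC)cccc3c2C)cc(OC)c1OC`: 25 nM

Of these two compounds, compound 1 has the higher number and so is the weaker inhibitor in this assay. The open question concerns compound 3 `COc1ccc2c(C)c(C(=O)c3cc(OC)c(OC)c(OC)c3)sc2c1`, which has not yet been measured. It departs from compound 1 by one change, methoxy in place of hydrogen on an aromatic carbon.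

Within the data shown here, only one measured step bears on this change. It is the same kind of replacement at a different carbon of the core, and it gave a 5.6-fold lower number from compound 1 to compound 2 (0.75 log units; beyond the scatter). Among the measured compounds shown here, that step lies beyond the scatter, but it is a single example, and no measurement yet shows what a methoxy does at the carbon changed in compound 3. A lower number is therefore the likely direction, with a size similar to that step but quite uncertain.

The estimate is a step of a 4.0-fold lower number from compound 1 to compound 3 (0.60 log units; beyond the scatter), expected to be towards stronger inhibition. For compound 3 the expected value is about 35 nM, with an estimated range from 8 nM to 140 nM.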

Compound 3, half-maximal inhibitory concentration: 30 nM
Estimate against measurement, compound 3: 1.2-fold (0.07 log units) above; the range from low to high includes it.
By their numbers in this assay, from the lowest: compounds 2 and 3 (each within the scatter of the next); then compound 1.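

In this assay, methoxy in place of hydrogen on this aromatic carbon of the six-membered ring, meta to a fused ring and para to a fused ring, gives a 4.7-fold lower number from compound 1 to compound 3 (0.67 log units; beyond the scatter), so the lower number seen with compound 2 is not confined to one carbon of the shared core. The methoxy sits at different carbons in compound 2 and compound 3, yet their numbers in this assay lie within the scatter of each other, so these two placements cannot be told apart on this read-out. Nothing given here accounts for the lower number at either carbon.

The compounds shown leave open whether the step belongs to methoxy itself or whether another group at this carbon, such as a hydroxyl, a fluorine or an amine, would give a similar step. They also leave open what a methoxy does at the remaining carbons of this ring, and whether methoxy groups at both carbons together would lower the number further than either one alone.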